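A few compounds are considered here, and "the series" means these few. Any claim that something is new, unique, unknown or untested is made for them only; others in the source may bear on it.

Working notes on a small series of furanone and pyrrolinone derivatives bearing two benzyloxy groups, tested in a functional assay on SW-620 cells (Homo sapiens) for antiproliferative activity, read by MTT assay, with a stated time of 72 h; on this read-out higher numbers stand for weaker inhibition and lower numbers for stronger inhibition.

Compound 1 `O=C1NC(O)(/C=C\n2cc(I)c3c(Cl)ncnc32)C(OCc2ccccc2)=C1OCc1ccccc1` gives 46900 nM in this assay. Compound 3 `COc1nc(OC)c2c(ccn2CCC2(O)NC(=O)C(OCc3ccccc3)=C2OCc2ccccc2)n1` gives 90700 nM in this assay. For compound 2 `O=C1O/C(=C\Cn2cnc3cc[nH]c3c2=O)C(OCc2ccccc2)=C1OCc1ccccc1` only a limit of the assay is recorded, > 100000 nM in this assay, so no number is known for it. Compound 2 therefore stands at the weak end of what is shown, at the limit of > 100000 nM in this assay, at which 1 of the 3 values shown sits, and the distance from it to compounds 1 and 3 cannot be set down as a measured step.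

Compound 4 `O=C1O/C(=C\Cn2cnc3ccnc(Cl)c32)C(OCc2ccccc2)=C1OCc1ccccc1` is the next compound to be measured in this assay. Relative to compound 2 the change is a group of 10 heavy atoms (6 carbon, 3 nitrogen, 1 chlorine; one five-membered aromatic ring with 2 hetero atoms, one six-membered aromatic ring with 1 hetero atom) in place of a group of 10 heavy atoms (6 carbon, 3 nitrogen, 1 oxygen; one five-membered aromatic ring with 1 hetero atom, one six-membered aromatic ring with 2 hetero atoms), on a saturated chain carbon bound to a double-bonded chain carbon. No step between two measured compounds of this series differs in one place only, so the expected size of the step must rest on the spread of the three numbers shown, of which compound 1 sits at 46900 nM and compound 3 at 90700 nM in this assay.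

The step from compound 2 to compound 4 is expected to be an at least 1.6-fold lower number from compound 2 to compound 4 (0.22 log units; that floor lies within the scatter), toward stronger inhibition, though a reading that is again only a limit remains quite possible. Compound 4 is estimated at 60000 nM in this assay, within a range of 25000 nM to 150000 nM.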

Compound 4, half-maximal inhibitory concentration: > 100000 nM
Compound 4: a limit, no number (the forecaster's own chance of this, stated with the estimate: 40%); at least 1.6-fold (0.22 log units) between middle value and limit.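

Within the data shown here, compound 4 gives only a limit of the assay, > 100000 nM in this assay, and compound 2 also stands at a limit, so no step between them can be read. The two compounds share one limit: the limit of > 100000 nM in this assay, at which 2 of the 4 values shown sit.

The compounds shown leave open how far compound 2 and compound 4 lie from each other, since neither has a number.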